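Moving the Methyl on the Anilino Ring of Compound 1

A few compounds are considered here, and "the series" means these few. Any claim that something is new, unique, unknown or untested is made for them only; others in the source may bear on it.

Compound 1 `COc1cccc(/C=C/C(=O)c2sc(Nc3cccc(C)c3)nc2C)c1` was tested in a functional assay on BGC-823 cells (Homo sapiens) for cytotoxicity, read by MTT assay; on this read-out lower numbers stand for stronger inhibition and higher numbers for weaker inhibition. There compound 1 reaches only the limit of the assay, > 25000 nM. Compound 2 `Cc1cccc(Nc2nc(C)c(C(=O)/C=C/c3ccccc3Cl)s2)c1` gives 24200 nM, and the step of an at least 1.0-fold lower number from compound 1 to compound 2 (0.01 log units; that floor lies within the scatter) cannot be read as a real change. Compound 3 `Cc1cccc(Nc2nc(C)c(C(=O)/C=C/c3ccc(Cl)cc3)s2)c1` again sits at a limit, > 25000 nM. The steps a step that the two limits leave unreadable from compound 1 to compound 3 and an at least 1.0-fold higher number from compound 2 to compound 3 (0.01 log units; that floor lies within the scatter) show nothing beyond the scatter either (the limit of > 25000 nM in this assay, at which 2 of the 3 values shown sit). Compound 4 `COc1cccc(/C=C/C(=O)c2sc(Nc3ccc(C)cc3)nc2C)c1` differs from compound 1 by 4-methylphenyl in place of 3-methylphenyl on a nitrogen on an aromatic ring. Among the measured compounds shown here, none of the measured steps touches this position; all three alter the aryl group on the double-bonded chain carbon, and every result stays near the limit. For compound 4 the step that the limit leaves unreadable from compound 1 to compound 4 is therefore expected to stay within the scatter. The estimate for compound 4 is 30000 nM, ranging from 15000 nM to 60000 nM.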

Compound 4, half-maximal inhibitory concentration: > 25000 nM
Compound 4 gave a limit, no number; the forecaster's own chance of this, stated with the estimate: 70%; the middle value lies beyond the limit too.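

Compound 1 and compound 4 both stop at a limit rather than a number, so the step between them cannot be read: the limit of > 25000 nM in this assay, at which 3 of the 4 values shown sit.

In this assay the compounds shown leave open whether 4-methylphenyl in place of 3-methylphenyl changes the result at all.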